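The compounds below may be only part of what the source reports. "The series", "measured", "known", "first", "only" and "open" are said of these compounds alone.

Of the compounds shown here, three sharing one core have been tested in an ADME assay on L6 cells (Rattus norvegicus) for cytotoxicity, read by resazurin assay, with a stated time of 72 h; a lower number here means a stronger inhibitor, a higher number a weaker inhibitor: compound 1 `CC(C)(C)c1ccc(C(=O)NC(=O)c2ccccc2O)cc1` gives 2.3 ug/mL, compound 2 `O=C(NC(=O)c1ccccc1O)c1ccc(OC(F)(F)F)cc1` gives 84 ug/mL, and compound 3 `COC(=O)c1ccc(C(=O)NC(=O)c2ccccc2O)cc1` gives 42 ug/mL. The last of these belongs to the upper pair of numbers. The gap within that pair is a 2.0-fold lower number from compound 2 to compound 3 (0.30 log units; within the scatter), while the distance to the tert-butyl compound is far greater, at an 18-fold higher number from compound 1 to compound 3 (1.26 log units; beyond the scatter).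

Compound 4 `CCN(CC)c1ccc(C(=O)NC(=O)c2ccccc2O)cc1` carries diethylamino in place of methoxycarbonyl on an aromatic carbon. Among the measured compounds shown here, no measured step makes this exact swap. The nearest evidence is the pair of large steps away from tert-butyl, a 37-fold higher number from compound 1 to compound 2 (1.56 log units; beyond the scatter) and an 18-fold higher number from compound 1 to compound 3 (1.26 log units; beyond the scatter). Diethylamino resembles tert-butyl in being built mostly of carbon and in having no oxygen, unlike the groups in the upper pair, so a partial move back towards compound 1 seems plausible, though three compounds are thin evidence. The expected change is a 5.3-fold lower number from compound 3 to compound 4 (0.72 log units; beyond the scatter), a clear drop but an uncertain one. The estimated value for compound 4 is 8 ug/mL, within a range of 2.5 ug/mL to 25 ug/mL.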

Compound 4, half-maximal inhibitory concentration: 8.2 ug/mL
Beside the measured number, compound 4's estimate is 1.0-fold (0.01 log units) below it, within the range that was stated.
By their numbers in this assay, from the lowest: compound 1; then compound 4; then compounds 3 and 2 (each within the scatter of the next).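

In this assay, among the compounds shown here, the earlier compounds split into one low number and an upper pair, and diethylamino now fills the space between them: the number falls on leaving methoxycarbonyl (a 5.1-fold lower number from compound 3 to compound 4 (0.71 log units; beyond the scatter)) and on leaving trifluoromethoxy (a 10-fold lower number from compound 2 to compound 4 (1.01 log units; beyond the scatter)), yet it does not reach the tert-butyl level (a 3.6-fold higher number from compound 1 to compound 4 (0.55 log units; beyond the scatter)). At this position, para to a large group, a low number is therefore not unique to tert-butyl, although tert-butyl still gives the lowest number of the four. Nothing measured here explains why these groups differ.

On these data alone, whether the ranking depends on the size of the group attached through nitrogen remains open, as a smaller dimethylamino group or a longer dipropylamino group would be needed to test it. As far as these compounds go, how a carboxylic acid or a piperidine ring would fall on this scale also remains unknown.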